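Swapping Isopropylsulfanyl for Cyclopentyloxy on the Carbonyl Carbon

The source may report more compounds than this note shows. Statements on the series, on what has been measured and on what is new or still open speak of the compounds shown alone.

Compound 3 `CC1=C(C(=O)SC(C)C)C(c2ccoc2)NC(=O)N1` gives 3% in an assay on membranes from HeLa cells for displacement of a labelled ligand from adenosine receptor A3 (Homo sapiens), read by scintillation counting, with a stated time of 180 min, tested at 1 uM; a higher number here means more inhibition at the concentration tested (going by the name of the read-out), a lower number less inhibition. On the numbers shown it stands level with compound 2 `CC1=C(C(=O)NC(C)C)C(c2ccoc2)NC(=O)N1`, which gives 3%, and the two are together the lowest of three values; compound 1 `CCCOC(=O)C1=C(C)NC(=O)NC1c1ccoc1` gives 11%. Compound 4 `CC1=C(C(=O)OC2CCCC2)C(c2ccoc2)NC(=O)N1` differs from compound 3 in one place: cyclopentyloxy in place of isopropylsulfanyl on a carbonyl carbon. Among the compounds with values here, three measured steps bear on this position, each exchanging the group on the same carbonyl carbon, and none moved beyond the scatter: a number 8 percentage points lower from compound 1 to compound 3 (within the scatter), a number 8 percentage points lower from compound 1 to compound 2 (within the scatter) and no change at the digits printed from compound 2 to compound 3 (within the scatter). Within the data shown here, no measured step brings in cyclopentyloxy, so its effect is open. The step of a number 3 percentage points higher from compound 3 to compound 4 (within the scatter) is therefore expected to be small. Compound 4 is estimated at 6%, with a range from 0% to 18% in this assay.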

Compound 4, a percentage reported as inhibition, at one concentration (the size of the read-out at that concentration, not a potency): 1%
Estimate against measurement, compound 4: 5 percentage points above; measured number inside the range.
By their numbers in this assay, from the lowest: compounds 4, 2, 3 and 1 (each within the scatter of the next).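

In this assay, cyclopentyloxy brings a five-membered non-aromatic ring to the carbonyl carbon, and the number stays within the scatter of the open-chain groups (a number 2 percentage points lower from compound 3 to compound 4 (within the scatter); a number 2 percentage points lower from compound 2 to compound 4 (within the scatter)). The step from the propyl ester also stays within the scatter (a number 10 percentage points lower from compound 1 to compound 4 (within the scatter)), so all four groups give numbers that cannot be told apart here. No evidence at hand accounts for this reading.

From the compounds shown here alone, whether a carboxylic acid or a longer chain such as hexyloxy on this carbonyl carbon would move the number beyond the scatter remains open. So does whether changes elsewhere on the shared core would do so.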